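Compound 4: swapping the aryl group on a barely toxic series

The source may report more compounds than this note shows. Statements on the series, on what has been measured and on what is new or still open speak of the compounds shown alone.

Results so far in a toxicity assay on THP-1 cells (Homo sapiens) for inhibition (on this read-out higher numbers stand for lower toxicity in this test and lower numbers for higher toxicity in this test), are these
Compound 1 `Cn1c(-c2ccc(Br)cc2)cnc1NC(=O)c1ccc(F)cc1` gives 46000 nM
Compound 2 `COc1ccc(-c2cnc(NC(=O)CCc3ccccc3)n2C)cc1` gives > 100000 nM as a limit
Compound 3 `Cn1cc(-c2ccccc2)nc1NC(=O)c1ccc(F)cc1` gives > 50000 nM as a limit

Within the data shown here, compound 1 holds the only true number here, as the other two results are limits and not numbers. The next compound, compound 4 `Cc1cccc(-c2cnc(NC(=O)c3ccc(F)cc3)n2C)c1`, keeps the core of compound 1 but carries 3-methylphenyl in place of 4-bromophenyl on an aromatic carbon of the five-membered ring. Among the measured compounds shown here, no two measured compounds differ in one place only, so the data offer no direct guide to this change. The nearest hint is compound 3, which stays at its limit (> 50000 nM) and gives no number. On that slim basis, a small move towards lower toxicity in this assay is expected, close to the usual scatter (a 1.4-fold higher number from compound 1 to compound 4 (0.15 log units; within the scatter)). Compound 4 is estimated at 65000 nM with an expected range (25000 nM to 150000 nM).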

Compound 4, half-maximal cytotoxic concentration: > 100000 nM
Compound 4 ended at the assay's limit; the forecaster's own chance of this, stated with the estimate: 55%; middle value at least 1.5-fold (0.18 log units) from the limit.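

In this assay, putting 3-methylphenyl in place of 4-bromophenyl on this aromatic carbon of the five-membered ring gives an at least 2.1-fold higher number from compound 1 to compound 4 (0.33 log units; beyond the scatter), the only step shown between compounds that differ in one place. Compound 4 gives > 100000 nM, which is a limit of the assay and not a number. Compound 1 thus remains the only compound here with a true number, and the step shows that at this position the aryl group can be changed with lower toxicity in this test, while its full size stays unknown: the limit of > 100000 nM in this assay, at which 2 of the 4 values shown sit.

The swap changes both the atom on the phenyl ring and its place, and the compounds shown cannot separate the two. Also open, on these data alone, is whether an amine or a carboxylic acid on that phenyl ring would give a true number in this assay or stay at the limit.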